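Adding a Methoxy to the Amide Phenyl of Compound 3

The source may report more compounds than this note shows. Statements on the series, on what has been measured and on what is new or still open speak of the compounds shown alone.

Compound 1, `C=CC1=C(C(=O)NCCC)C(c2ccc(Cl)c(Cl)c2)OC1`, in a functional assay on HeLa cells (Homo sapiens) for cytotoxicity, read by MTT assay, with a stated time of 24 h (a higher number here means a weaker inhibitor, a lower number a stronger inhibitor), gives > 100000 nM, which is a limit of the assay and not a number.
Compound 2, `C=CC1=C(C(=O)NCC(C)C)C(c2ccc(Cl)c(Cl)c2)OC1`, in this assay gives 60100 nM.
Compound 3, `C=CC1=C(C(=O)Nc2ccccc2)C(c2ccc(Cl)c(Cl)c2)OC1`, in this assay gives > 100000 nM, again a limit of the assay.

All three share one core and differ only in the group on the amide-type nitrogen. Compound 3 stands where the assay returns no number; it shares that position with compound 1, as the limit of > 100000 nM in this assay, at which 2 of the 3 values shown sit, records. Going from compound 1 to compound 2 gives an at least 1.6-fold lower number from compound 1 to compound 2 (0.22 log units; that floor lies within the scatter); going from compound 2 to compound 3 gives an at least 1.6-fold higher number from compound 2 to compound 3 (0.22 log units; that floor lies within the scatter); from compound 1 to compound 3 the two limits give a step that the two limits leave unreadable from compound 1 to compound 3.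

Compound 4, `C=CC1=C(C(=O)Nc2ccccc2OC)C(c2ccc(Cl)c(Cl)c2)OC1`, differs from compound 3 by methoxy in place of hydrogen on an aromatic carbon. Among the measured compounds shown here, no measured step alters a substituent on the phenyl; the measured steps swap the whole group on the amide-type nitrogen, and the one that leads to compound 3 ends at a limit. Compound 4 is therefore expected to remain near that limit, with no step beyond the scatter. The step this expectation means is a step that the limit leaves unreadable from compound 3 to compound 4. The estimate for compound 4 in this assay is 150000 nM, with a range from 60000 nM to 400000 nM.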

Compound 4, half-maximal inhibitory concentration: > 100000 nM
Compound 4 ended at the assay's limit; the forecaster's own chance of this, stated with the estimate: 70%; the middle value does not contradict the limit.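

A methoxy on an aromatic carbon of the amide phenyl, ortho to a large group, is the only change shown that alters the phenyl and does not swap the whole group on the amide-type nitrogen, and in this assay compound 4 gives > 100000 nM as a limit of the assay and not a number. The steps to compound 4 from compound 1 and compound 3 cannot be read, so this methoxy has no measurable size here, and it did not bring the phenyl amide to a number within the range of the assay. Among the compounds shown here, the one readable step, 2-methoxyphenyl in place of isobutyl, is an at least 1.6-fold higher number from compound 2 to compound 4 (0.22 log units; that floor lies within the scatter) and so stays too small to rank the two groups, while the series gathers further at one end of the range: the limit of > 100000 nM in this assay, at which 3 of the 4 values shown sit.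

Going by these compounds, whether a methoxy at this place changes cytotoxicity at all stays open while neither phenyl compound gives a number. Also open, on these data alone, is how an amine or a carboxylic acid on the phenyl, or a longer chain on the amide-type nitrogen, would read in this assay against the isobutyl compound.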